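The compounds below may be only part of what the source reports. "The series", "measured", "known", "first", "only" and "open" are said of these compounds alone.

Compound 1 `CCOc1nc(N)nc2c1ncn2/C=C1/CC1(CO)CO`: > 20000 nM
Compound 2 `CCCNc1nc(N)nc2c1ncn2/C=C1/CC1(CO)CO`: > 24000 nM
Compound 3 `CCCCCOc1nc(N)nc2c1ncn2/C=C1/CC1(CO)CO`: > 20000 nM
Compound 4 `CCCCSc1nc(N)nc2c1ncn2/C=C1/CC1(CO)CO`: not yet measured

All three measured compounds were tested in an ADME assay on Akata cells (Homo sapiens) for cytotoxicity, with a stated time of 7 days (a lower number here means that less compound is tolerated, a higher number that more compound is tolerated), and none of them gave an exact number. Compound 1 gives > 20000 nM, which is a limit. Compound 2 gives > 24000 nM, which is also a limit. Compound 3 gives > 20000 nM, again a limit, so it stands at the limit of > 20000 nM in this assay, at which 2 of the 3 values shown sit. The other limit seen is the limit of > 24000 nM in this assay, at which 1 of the 3 values shown sits.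

Compound 4 carries butylsulfanyl in place of pentyloxy on an aromatic carbon. Among the compounds with values here, three measured steps bear on this change, all of them swaps among the groups on that carbon: a step that the two limits leave unreadable from compound 1 to compound 2, a step that the two limits leave unreadable from compound 1 to compound 3 and a step that the two limits leave unreadable from compound 2 to compound 3. Within the data shown here, none of them offers a size to carry over, and none of the measured compounds has butylsulfanyl, so the forecast rests on limits alone. In this assay, no step beyond the usual scatter is therefore expected, and no direction can be favoured. The estimated change is a number no higher from compound 3 to compound 4 (the limit leaves the size open). Compound 4 is expected to give about 20000 nM, within an estimated range of 8000 nM to 40000 nM. The result may well turn out to be another limit.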

Compound 4, half-maximal cytotoxic concentration: > 20000 nM
Compound 4: a limit, no number (the forecaster's own chance of this, stated with the estimate: 80%); the middle value lies on the limit itself.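

In this assay compound 4 gives > 20000 nM, which is a limit. Compound 1, compound 2 and compound 3 also gave limits, so the steps from each of them to compound 4 cannot be read. The compounds shown leave open the concentration at which any of them harms these cells, and whether swapping ethoxy, propylamino, pentyloxy and butylsulfanyl on that aromatic carbon changes it.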